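The source may hold more compounds than are shown below. What is called first, only, known or untested is meant among the compounds shown, and "the series" means these compounds.

Measured compounds in a functional assay on A2780 cells (Homo sapiens) for inhibition, read by sulforhodamine B assay, with a stated time of 96 h; on this read-out higher numbers stand for weaker inhibition of growth and lower numbers for stronger inhibition of growth:
compound 1, `CC[C@H](Nc1nc(NCc2ccccn2)c2ncn(C(C)C)c2n1)C(C)(C)O`, gives 19000 nM
compound 2, `CC[C@H](Nc1nc(NCc2ccccn2)c2ncn(C(C)C)c2n1)C(C)O`, gives 10000 nM

Within the data shown here, compound 2 and compound 1 stand within the scatter of one another: the step of a 1.9-fold lower number from compound 1 to compound 2 (0.28 log units; within the scatter) is too small to tell the two numbers apart, and compound 1 is the only neighbour compound 2 has. Compound 3, `CC[C@@H](Nc1nc(NCc2ccccn2)c2ncn(C(C)C)c2n1)C(O)C(C)(C)C`, has not yet been measured in this assay. It differs from compound 2 by 1-ethyl-2-hydroxy-3,3-dimethylbutyl in place of 1-(1-hydroxyethyl)propyl on a nitrogen on an aromatic ring. Among the measured compounds shown here, the one measured step, a 1.9-fold lower number from compound 1 to compound 2 (0.28 log units; within the scatter), alters the same side chain at a saturated chain carbon bound to an oxygen and stays within the scatter, so it gives no sign that the make-up of this chain moves the number much. For the measured compounds named here, the change to compound 3 is a larger one, exchanging the whole chain, and no measured step bears on it closely; the expected step of a 1.3-fold lower number from compound 2 to compound 3 (0.10 log units; within the scatter) is therefore set within the scatter of compound 2. Going by these compounds, compound 3 is estimated at 8000 nM, with a range from 2500 nM to 30000 nM that is kept wide because the extra carbons of the new chain are untested.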

Compound 3, concentration for 50% growth inhibition: 23000 nM
Estimate against measurement, compound 3: 2.9-fold (0.46 log units) below; the range from low to high includes it.
By their numbers in this assay, from the lowest: compounds 2, 1 and 3 (each within the scatter of the next, the first and the last beyond it).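

In this assay, among these compounds, 1-ethyl-2-hydroxy-3,3-dimethylbutyl in place of 1-(1-hydroxyethyl)propyl on the nitrogen gives a 2.3-fold higher number from compound 2 to compound 3 (0.36 log units; beyond the scatter), the first step in this side chain to lie beyond the scatter, which shows that exchanging the chain at this position can shift the number, though only modestly. Set against the 1-(1-hydroxy-1-methylethyl)propyl chain, the same new chain gives a 1.2-fold higher number from compound 1 to compound 3 (0.08 log units; within the scatter), so that exchange cannot be told apart from no change, and the shift rests on a single pair whose two members both lie within the scatter of compound 1. Nothing available gives a reason for the shift seen with the new chain.

All three compounds carry a hydroxy group on the side chain, so the compounds shown leave open whether an amine or a carboxylic acid in its place would alter the number in this assay. They also leave open how a chain with no hydroxy group at all, such as a plain butyl chain, would compare on this nitrogen.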